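Ethylsulfanyl variant of a nitro-bearing triazole-fused urea series

The source may hold more compounds than are shown below. What is called first, only, known or untested is meant among the compounds shown, and "the series" means these compounds.

Measured compounds in a functional assay on RD cells (Homo sapiens) for inhibition, read by MTT assay, with a stated time of 72 h; a lower number here means a stronger inhibitor, a higher number a weaker inhibitor:
Compound 1, `CCN1C(=O)N(CC)C2C1N=C(SC)N2/N=C/C=C/c1ccccc1`, compound 1 gives 24000 nM.
Compound 2, `CCN1C(=O)N(CC)C2C1N=C(SC)N2/N=C/C=C/c1ccccc1[N+](=O)[O-]`, compound 2 gives 41900 nM.

Among the compounds with values here, the one measured step, a 1.7-fold higher number from compound 1 to compound 2 (0.24 log units; within the scatter), concerns the nitro group and lies within the scatter. Compound 2 holds the highest of the two numbers, with compound 1 nearest.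

Compound 3, `CCSC1=NC2C(N(CC)C(=O)N2CC)N1/N=C/C=C/c1ccccc1[N+](=O)[O-]`, differs from compound 2 by methyl in place of hydrogen on a saturated chain carbon bound to a sulfur. No measured step touches the methylsulfanyl group, so nothing shown speaks for or against a shift. The expectation for compound 3 in this assay is therefore a step of a 1.0-fold higher number from compound 2 to compound 3 (0.00 log units; within the scatter), no change beyond the scatter. Compound 3 is estimated at 42000 nM, within 20000 nM to 90000 nM.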

Compound 3, half-maximal inhibitory concentration: 2450 nM
For compound 3 the middle estimate is 17-fold (1.23 log units) above the measured one; measured number below the stated range.
By their numbers in this assay, from the lowest: compound 3; then compounds 1 and 2 (each within the scatter of the next).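

In this assay the change from methylsulfanyl to ethylsulfanyl gives a 17-fold lower number from compound 2 to compound 3 (1.23 log units; beyond the scatter), while the nitro change, a 1.7-fold higher number from compound 1 to compound 2 (0.24 log units; within the scatter), stays within the scatter. The saturated chain carbon bound to a sulfur is therefore a place where one added methyl moves the number strongly, at least with the nitro group present. Nothing at hand accounts for the shift.

From the compounds shown here alone, whether a longer chain such as propyl, or a branched isopropyl, lowers the number further remains open. Also open, going by these compounds, is whether ethylsulfanyl has the same effect without the nitro group.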